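Amino in place of nitro on the shared core

This account rests on a few compounds, and the source may have more. Where it says the series, first, only, none or still open, it means among the compounds named here.

Measured compounds:
compound 1 `O=[N+]([O-])c1cccc(CNc2cc(Br)cc3[nH]ncc23)c1`, 72%
compound 2 `O=[N+]([O-])c1cccc(CNc2cc(C(F)(F)F)cc3[nH]ncc23)c1`, 45%
compound 3 `O=[N+]([O-])c1ccc(O)cc1CNc1cc(Br)cc2[nH]ncc12`, 92%

Of the compounds shown here, three have been measured in an assay for inhibition of Indoleamine 2,3-dioxygenase 1 (Homo sapiens), with stated times of 10 min and 60 min, tested at 10 uM; a higher number here means a stronger effect of the compound at the concentration tested, a lower number a weaker effect. Compound 1 gives 72%, compound 2 gives 45% and compound 3 gives 92%. Among the compounds with values here, compound 2 stands lowest of the three; the one measured step that reaches it, a number 27 percentage points lower from compound 1 to compound 2 (beyond the scatter), is a modest fall and lies beyond the scatter. Compound 3 and compound 1 differ in more than one place, so their two values are simply shown side by side.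

Compound 4 `Nc1cccc(CNc2cc(C(F)(F)F)cc3[nH]ncc23)c1` has not yet been measured. It differs from compound 2 in one place: amino in place of nitro on an aromatic carbon. Within the data shown here, none of the measured steps swaps the nitro group for anything else, so no measured step bears on this change, and the trifluoromethyl group of compound 2 is kept. With nothing to lean on, the expected step of a number 5 percentage points lower from compound 2 to compound 4 (within the scatter) is none beyond the scatter, in either direction. Compound 4 is therefore estimated at 40% in this assay, within a wide range from 10% to 70%.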

Compound 4, a percentage reported as inhibition, at one concentration (the size of the read-out at that concentration, not a potency): 24%
Beside the measured number, compound 4's estimate is 16 percentage points above it, within the range that was stated.
By their numbers in this assay, from the lowest: compound 4; then compound 2; then compound 1; then compound 3.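

Amino in place of nitro gives a number 21 percentage points lower from compound 2 to compound 4 (beyond the scatter) in this assay, which shows for the first time that this aromatic carbon is sensitive to the group it carries. Together with a number 27 percentage points lower from compound 1 to compound 2 (beyond the scatter), it means that both single changes available for comparison lower the number, one at the bromo or trifluoromethyl position and the other at the nitro position. Nothing available explains why the amino compound gives the lower number.

As far as these compounds go, it remains open whether amino in place of nitro would have a similar effect with bromo on the shared core instead of trifluoromethyl. It is also unknown how other groups on this aromatic carbon, such as a nitrile, a carboxylic acid or a methoxy group, would compare with nitro and amino.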